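This account rests on a few compounds, and the source may have more. Where it says the series, first, only, none or still open, it means among the compounds named here.

Measured so far in a toxicity assay on J774.1 cells (Mus musculus) for cytotoxicity, read by MTT assay, with a stated time of 48 h; on this read-out lower numbers stand for higher toxicity in this test and higher numbers for lower toxicity in this test:
compound 1 `CC(=O)N(Cc1ccccc1C(=O)N[C@H](/C=C/S(=O)(=O)c1ccccc1)CCc1ccccc1)C(C)=O` — 36000 nM
compound 2 `O=C(NCc1ccccc1C(=O)N[C@H](/C=C(\F)S(=O)(=O)Oc1ccccc1)CCc1ccccc1)c1ccncc1` — > 100000 nM (a limit)

Among the compounds with values here, compound 1 gives 36000 nM in this assay, the only plain number in the set. Compound 2 reaches a limit of this assay with > 100000 nM, which is the limit of > 100000 nM in this assay, at which 1 of the 2 values shown sits. Compound 3 `O=C(O)c1cccc(C(=O)NCc2ccccc2C(=O)N[C@H](/C=C/S(=O)(=O)c2ccccc2)CCc2ccccc2)c1` differs from compound 1 by ((3-carboxyphenyl)carbonyl)amino in place of diacetylamino on a saturated chain carbon bound to an aromatic carbon. Within the data shown here, no measured step covers this change, so the expected step of a 1.9-fold higher number from compound 1 to compound 3 (0.29 log units; within the scatter) is small and toward lower toxicity, with a fair chance that only a limit is reported. Compound 3 is estimated at 70000 nM, in the range 25000 nM to 200000 nM.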

Compound 3, half-maximal cytotoxic concentration: > 100000 nM
Compound 3: only a limit was reported (the forecaster's own chance of this, stated with the estimate: 45%); middle value at least 1.4-fold (0.15 log units) from the limit.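

In this assay, within the data shown here, the replacement of diacetylamino by ((3-carboxyphenyl)carbonyl)amino on a saturated chain carbon bound to an aromatic carbon gives an at least 2.7-fold higher number from compound 1 to compound 3 (0.44 log units; beyond the scatter), the only measured step at this place. For compound 3 the reading is a limit, so the step fixes a direction toward lower toxicity and not a size. The series now gathers at one end of the read-out: the limit of > 100000 nM in this assay, at which 2 of the 3 values shown sit.

Going by these compounds, whether the carboxylic acid or the added aromatic ring carries the step stays open. A plain benzoylamino group at this place would separate the two.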